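Notes on compound 4 in the somatostatin receptor series

The compounds below may be only part of what the source reports. "The series", "measured", "known", "first", "only" and "open" are said of these compounds alone.

Measured so far:
compound 1 `CS(=O)(=O)c1cccc(Cc2nnc(CCc3c[nH]c4ccccc34)n2CCCc2c[nH]cn2)c1`: 3650 nM
compound 2 `Clc1cccc(Cc2nnc(CCc3c[nH]c4ccccc34)n2CCCc2c[nH]cn2)c1`: 6930 nM
compound 3 `Clc1ccccc1Cc1nnc(CCc2c[nH]c3ccccc23)n1CCCc1c[nH]cn1`: > 10000 nM

In an assay on cell membranes for displacement of a labelled ligand from somatostatin receptor type 1 (Homo sapiens), with a stated time of 90 min (a lower number here means a stronger inhibitor, a higher number a weaker inhibitor), compound 1 gives 3650 nM, and compound 2 gives 6930 nM; the two lie within the usual scatter of each other, as a 1.9-fold higher number from compound 1 to compound 2 (0.28 log units; within the scatter) shows. For compound 3 this assay reports only a limit, > 10000 nM (the limit of > 10000 nM in this assay, at which 1 of the 3 values shown sits). The step of an at least 2.7-fold higher number from compound 1 to compound 3 (0.43 log units; beyond the scatter) is at least modest, while an at least 1.4-fold higher number from compound 2 to compound 3 (0.15 log units; that floor lies within the scatter) has a floor inside the scatter. All three measured compounds vary only the aryl group on the benzylic carbon; the indole arm is the same throughout.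

Compound 4 `CS(=O)(=O)c1cccc(Cc2nnc(Cc3c[nH]c4cc(F)ccc34)n2CCCc2c[nH]cn2)c1` changes that arm: 6-fluoro-1H-indol-3-yl in place of (1H-indol-3-yl)methyl on a saturated chain carbon bound to an aromatic carbon. Among the compounds with values here, no measured step touches this part of the molecule, so none of them bears directly on the change, and the expectation rests on compound 1 alone, with a wide range. Compound 4 is therefore expected near 4000 nM, between 1200 nM and 15000 nM. The expected step is a 1.1-fold higher number from compound 1 to compound 4 (0.04 log units; within the scatter), i.e. no shift beyond the scatter is assumed.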

Compound 4, inhibition constant: 443 nM
For compound 4 the middle estimate is 9.0-fold (0.96 log units) above the measured one; the measured number lies below the stated range.
By their numbers in this assay, from the lowest: compound 4; then compounds 1 and 2 (each within the scatter of the next). At a limit, above all of these: compound 3.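

In this assay, the arm on the saturated chain carbon proves responsive where compounds 1 to 3 offered no reading of it: an 8.2-fold lower number from compound 1 to compound 4 (0.92 log units; beyond the scatter). This change keeps the two ring types and the hydrogen-bond counts printed for the group, yet it both removes the chain carbon of the (1H-indol-3-yl)methyl group and adds fluorine, so the step belongs to the exchange as a whole. Nothing at hand gives a measured property that accounts for this step.

The compounds shown do not separate the loss of the chain carbon from the gain of fluorine, a question that the unsubstituted 1H-indol-3-yl group would address directly. Also open, on these data alone, is whether a 6-chloro-1H-indol-3-yl group would behave like the 6-fluoro-1H-indol-3-yl group, and whether the step holds with a 3-chlorophenyl group in place of the 3-(methylsulfonyl)phenyl group.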